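Coumarin ester series: benzylic chloride replacing acetoxy

The compounds below may be only part of what the source reports. "The series", "measured", "known", "first", "only" and "open" are said of these compounds alone.

Measured so far in a functional assay on HT-1080 cells (Homo sapiens), read by transwell migration, with a stated time of 24 h, tested at 1 uM; on this read-out lower numbers stand for a stronger effect and higher numbers for a weaker effect at the one concentration tested:
compound 1 `CC(=O)OCc1ccc2oc(=O)c(C(=O)Oc3cccc(Cl)c3)cc2c1`, 49.1%
compound 2 `CC(=O)OCc1ccc2oc(=O)c(C(=O)Sc3cccc(Br)c3)cc2c1`, 70.9%
compound 3 `CC(=O)OCc1ccc2oc(=O)c(C(=O)Nc3cccc(Cl)c3)cc2c1`, 66.9%

Compound 1 gives the lowest number of the three in this assay, and both of its steps to the other two are beyond the scatter: a number 21.8 percentage points higher from compound 1 to compound 2 (beyond the scatter) and a number 17.8 percentage points higher from compound 1 to compound 3 (beyond the scatter). Compounds 2 and 3 sit within the scatter of each other, a number 4 percentage points lower from compound 2 to compound 3 (within the scatter).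

The unmeasured compound 4 `O=C(Oc1cccc(Cl)c1)c1cc2cc(CCl)ccc2oc1=O` differs from compound 1 at the other end of the shared core: chloro in place of acetoxy on a saturated chain carbon bound to an aromatic carbon. The three measured steps all concern the group attached to the carbonyl carbon, and none touches the saturated chain carbon bound to an aromatic carbon. Within the data shown here, they therefore say nothing about the size or direction of the present step; the only guide is the value of compound 1 itself, 49.1%, which is carried over as the starting point.

Among the measured compounds shown here, with no step of this kind on record, the expected change in this assay is none beyond the scatter, and the estimate for compound 4 is 52%, in a wide range from 30% to 75%, meaning an expected step of a number 2.9 percentage points higher from compound 1 to compound 4 (within the scatter). For the measured compounds named here, this expectation rests on no pair among compounds 1, 2 and 3, since none of their steps concerns this position.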

Compound 4, a percentage reported as activity, at one concentration (the size of the read-out at that concentration, not a potency): 79.8%
Estimate against measurement, compound 4: 27.8 percentage points below, and the stated range ends below it.
By their numbers in this assay, from the lowest: compound 1; then compounds 3, 2 and 4 (each within the scatter of the next, the first and the last beyond it).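

Working from this assay, the saturated chain carbon bound to an aromatic carbon proves to be a responsive position: acetoxymethyl to chloromethyl gives a number 30.7 percentage points higher from compound 1 to compound 4 (beyond the scatter) and is beyond the scatter, so the read-out depends on this end of the shared core as well as on the group on the carbonyl carbon. With 3-chlorophenoxy held constant, chloro in place of acetoxy gives a weaker effect at the one concentration tested, and compound 1 retains the lowest number of the four compounds. No available evidence explains this step, and the change alone cannot separate the loss of acetoxy from the arrival of chloro.

Still open, on these data alone, is whether other groups at this place, such as hydroxy, methoxy, an amine or a longer ester like propanoyloxy, stay near compound 1 or move towards compound 4. Also open, as far as these compounds go, is whether the same exchange of acetoxy for chloro gives a step of similar size and direction when (3-chlorophenyl)amino or (3-bromophenyl)sulfanyl sits on the carbonyl carbon, and how the change behaves at other concentrations.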